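The source may hold more compounds than are shown below. What is called first, only, known or untested is meant among the compounds shown, and "the series" means these compounds.

Measured in a functional assay on HepG2 cells (Homo sapiens) for cytotoxicity, read by MTT assay, with a stated time of 72 h; a higher number here means a weaker inhibitor, a lower number a stronger inhibitor:
- Compound 1 `O=C(N/N=C/c1ccc(F)cc1)Nc1cc2c(Nc3ccc(F)c(Cl)c3)ncnc2cc1O[C@H]1CCOC1`: "not active" (no number reported)
- Compound 2 `O=C(N/N=C/c1cccc(Br)c1)Nc1cc2c(Nc3ccc(F)c(Cl)c3)ncnc2cc1O[C@H]1CCOC1`: 32300 nM
- Compound 3 `N#Cc1ccc(/C=N/NC(=O)Nc2cc3c(Nc4ccc(F)c(Cl)c4)ncnc3cc2O[C@H]2CCOC2)cc1`: 26400 nM

In this assay, compound 3 gives 26400 nM, within the scatter of compound 2, while compound 1 yields no number. Compound 4 `O=C(N/N=C/c1ccc([N+](=O)[O-])cc1)Nc1cc2c(Nc3ccc(F)c(Cl)c3)ncnc2cc1O[C@H]1CCOC1` differs from compound 3 in one place: nitro in place of cyano on an aromatic carbon. This is nitro in place of cyano on an aromatic carbon, para to a large group. Within the data shown here, one measured step bears on it, and only indirectly: a 1.2-fold lower number from compound 2 to compound 3 (0.09 log units; within the scatter). It exchanges one aryl group for another without a shift beyond the scatter. Nothing beyond the scatter is therefore expected, and the estimated change is a 1.1-fold lower number from compound 3 to compound 4 (0.02 log units; within the scatter). Compound 4 is expected at 25000 nM, with an estimated range of 11000 nM to 60000 nM.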

Compound 4, half-maximal inhibitory concentration: 35300 nM
Compound 4: the middle estimate sits 1.4-fold (0.15 log units) below what was measured; the measured number falls inside the stated range.
By their numbers in this assay, from the lowest: compounds 3, 2 and 4 (each within the scatter of the next).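

In this assay, nitro on this aromatic carbon, para to a large group, gives a value that cyano does not separate from (a 1.3-fold higher number from compound 3 to compound 4 (0.13 log units; within the scatter)). The 4-nitrophenyl group also stays within the scatter of the 3-bromophenyl group (a 1.1-fold higher number from compound 2 to compound 4 (0.04 log units; within the scatter)), so compounds 2, 3 and 4 cannot be ranked, while compound 1 still has no number to compare. On these data alone, whether an amine or a carboxylic acid on this carbon would move the value beyond the scatter remains open. No measurement shown here explains the result.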